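Chain-extended ether acid on the difluoro core

A few compounds are considered here, and "the series" means these few. Any claim that something is new, unique, unknown or untested is made for them only; others in the source may bear on it.

Compound 1 `CO[C@H]1C[C@H](Oc2ccc([N+](=O)[O-])c(-c3cc(F)c(OCCCC(=O)O)c(F)c3)c2)C1` gives 29400 nM in a functional assay on CHO cells for agonist activity at Free fatty acid receptor 1 (Homo sapiens), read by calcium flux; a lower number here means that less compound is needed, a higher number that more compound is needed for the effect. Compound 2 `CO[C@H]1C[C@H](Oc2cc(F)c(F)c(-c3cc(F)c(SCCCC(=O)O)c(F)c3)c2)C1` carries a thioether link to its acid chain on a doubly fluorinated core. In this assay compound 2 gives only the limit > 100000 nM, not a number, so that compound 2 sits at the limit of > 100000 nM in this assay, at which 1 of the 2 values shown sits, the upper edge of what was measured. Compound 3 `CO[C@H]1C[C@H](Oc2cc(F)c(F)c(-c3cc(F)c(OCCCCCCC(=O)O)c(F)c3)c2)C1` is the unmeasured member of the pair; it differs from compound 2 by (6-carboxyhexyl)oxy in place of (3-carboxypropyl)sulfanyl on an aromatic carbon. Within the data shown here, no measured step of this sort exists. The expected step from compound 2 to compound 3 is a gain, the estimate being an at least 1.6-fold lower number from compound 2 to compound 3 (0.22 log units; that floor lies within the scatter), because compound 1 with an ether-linked acid chain reached a measurable 29400 nM while the thioether of compound 2 did not. The estimate for compound 3 in this assay is 60000 nM, expected to fall between 15000 nM and 300000 nM, with a real chance that only a limit is returned.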

Compound 3, half-maximal effective concentration: 3500 nM
Compound 3: the middle estimate sits 17-fold (1.23 log units) above what was measured, outside the stated range (below it).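

The position on the aromatic carbon, ortho to two fluoro groups and para to a large group, now proves responsive in this assay: (6-carboxyhexyl)oxy in place of (3-carboxypropyl)sulfanyl gives an at least 28-fold lower number from compound 2 to compound 3 (1.45 log units; beyond the scatter). The size of that step is only a floor, since one end of it is not a number: the limit of > 100000 nM in this assay, at which 1 of the 3 values shown sits. The change swaps the sulfur link for an oxygen link and lengthens the chain in one move, and the step belongs to the whole group, not to either part alone.

Open, on these data alone, is how the step divides between link and length, which (3-carboxypropyl)oxy or (6-carboxyhexyl)sulfanyl on the same core would help to settle. Also open, as far as these compounds go, is how a longer chain, or an amide in place of the carboxylic acid, would read here.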